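Methoxy in Place of Chloro: Expected Cytotoxicity of Compound 4

The source may report more compounds than this note shows. Statements on the series, on what has been measured and on what is new or still open speak of the compounds shown alone.

Compound 1 `COc1ccc(NC(=O)COC(=O)/C=C/c2cc(OC)c(OCc3ccc(Cl)c(Cl)c3)c(OC)c2)cc1` in a functional assay on ECa-109 cells (Homo sapiens) for cytotoxicity, read by MTT assay, with a stated time of 72 h (on this read-out higher numbers stand for weaker inhibition and lower numbers for stronger inhibition), gives > 200000 nM, which is a limit of the assay.
Compound 2 `COc1cc(/C=C/C(=O)OCC(=O)Nc2ccc(Cl)cc2)cc(OC)c1OCc1ccc(Cl)c(Cl)c1` in this assay gives > 200000 nM, which is also a limit of the assay.
Compound 3 `O=C(COC(=O)/C=C/c1ccc(O)c(O)c1)Nc1ccc(Cl)cc1` in this assay gives 175000 nM.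

Among the measured compounds shown here, compound 3 thus shows the only number in this set; the other two values are limits. The difference between the cores of compound 3 and compound 2 is not broken down here. Compound 4 `COc1ccc(NC(=O)COC(=O)/C=C/c2ccc(O)c(O)c2)cc1` has not yet been measured in this assay. It differs from compound 3 by methoxy in place of chloro on an aromatic carbon. The same change separates compound 2 from compound 1, (methoxy in place of chloro on an aromatic carbon), and among the compounds shown it occurs twice. The step it made there, a step that the two limits leave unreadable from compound 2 to compound 1, cannot be sized because the limit of > 200000 nM in this assay, at which 2 of the 3 values shown sit, is where both of those values sit. With no readable measured instance of this change, the expected step is a 1.1-fold higher number from compound 3 to compound 4 (0.04 log units; within the scatter), resting on compound 3 sitting at 175000 nM in this assay. In this assay compound 4 is therefore estimated at 190000 nM, within a range of 90000 nM to 400000 nM, with a real chance that only a limit is reported.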

Compound 4, half-maximal inhibitory concentration: 190000 nM
Estimate against measurement, compound 4: no gap at the digits printed; low and high end bracket the measured number.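

In this assay, methoxy in place of chloro on an aromatic carbon, read here as 4-chlorophenyl to 4-methoxyphenyl, gives a 1.1-fold higher number from compound 3 to compound 4 (0.04 log units; within the scatter), so on the core of compound 3 this change makes no difference that can be told from the scatter. Among the compounds shown here, the same change on the core of compound 2 stays unread, so the series offers no second step to set beside this one, since compound 1 and compound 2 both give only a limit of the assay and not a number: the limit of > 200000 nM in this assay, at which 2 of the 4 values shown sit. One readable step on one core therefore shows what the change does there and gives no measure of how it carries to another core.

The compounds shown leave open what an amine or a carboxylic acid in place of the chloro would do at the same place on the core of compound 3. They also leave open whether a longer chain in place of the methoxy of compound 4 would give a step beyond the scatter.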